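This account rests on a few compounds, and the source may have more. Where it says the series, first, only, none or still open, it means among the compounds named here.

In a functional assay on MCF7 cells (Homo sapiens) for inhibition, read by MTT assay, with a stated time of 72 h (on this read-out lower numbers stand for stronger inhibition and higher numbers for weaker inhibition), compound 1 `CCC(=O)O[C@@H](/C(C)=C/[C@@H](C)c1oc(CC)c(C)c(=O)c1C)[C@H](C)[C@@H](OC(=O)CC(C)C)[C@@H](C)c1oc([C@@H](C)[C@@H](O)CC)c(C)c(=O)c1C` gives 12000 nM. Compound 3 `CCC(=O)[C@H](C)c1oc([C@H](C)[C@@H]2O[C@](O)([C@@H](C)c3oc(CC)c(C)c(=O)c3C)[C@@H](C)[C@@H](OC(=O)CC(C)C)[C@@H]2C)c(C)c(=O)c1C` gives 21000 nM, which lies within the scatter of compound 1. Compound 2 `CCC(=O)[C@H](C)c1oc([C@H](C)[C@@H]2O[C@](O)([C@@H](C)c3oc(CC)c(C)c(=O)c3C)[C@@H](C)[C@@H](O)[C@@H]2C)c(C)c(=O)c1C` reads > 100000 nM, which is a limit of the assay and not a number.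

Compound 4 `CCc1oc([C@H](C)/C=C(\C)[C@H](OC(C)=O)[C@H](C)[C@@H](OC(=O)CC(C)C)[C@@H](C)c2oc([C@@H](C)[C@@H](O)CC)c(C)c(=O)c2C)c(C)c(=O)c1C` differs from compound 1 in one place: hydrogen in place of methyl on a saturated chain carbon bound to a carbonyl carbon. This is hydrogen in place of methyl on a saturated chain carbon bound to a carbonyl carbon, so propanoyloxy becomes acetoxy.

For the measured compounds named here, only one measured step comes near this change: an at least 4.7-fold lower number from compound 2 to compound 3 (0.67 log units; beyond the scatter), with isobutylcarbonyl in place of hydrogen on an oxygen on a saturated carbon. That step adds a whole ester to a free hydroxyl, whereas compound 4 keeps its ester in a shortened form, so the step is only a loose guide. No shift beyond the scatter is therefore expected, and the estimate stays close to compound 1 at 12000 nM.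

The expected change is a 1.1-fold higher number from compound 1 to compound 4 (0.03 log units; within the scatter). Compound 4 is estimated at 13000 nM, with an expected range from 5000 nM to 35000 nM.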

Compound 4, half-maximal inhibitory concentration: 15000 nM
Compound 4: middle estimate off by 1.2-fold (0.06 log units), on the low side, and the stated range covers the measured number.
By their numbers in this assay, from the lowest: compounds 1, 4 and 3 (each within the scatter of the next). At a limit, above all of these: compound 2.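

In this assay the swap of propanoyloxy for acetoxy, hydrogen in place of methyl on a saturated chain carbon bound to a carbonyl carbon, shows a 1.3-fold higher number from compound 1 to compound 4 (0.10 log units; within the scatter) and so leaves the two compounds indistinguishable. For the compounds shown here, this is the first look at this ester: the earlier readable step concerned isobutylcarbonyl in place of hydrogen on an oxygen, and it says nothing about shortening the propanoyloxy group by one methyl. Nothing measured here explains why this methyl makes no readable difference.

Only this single shortening is shown at this position, so a longer chain such as butanoyloxy or a bulkier ester such as isobutylcarbonyloxy could still read differently. From the compounds shown here alone, a free hydroxyl or an amine in place of the ester also remains open.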